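This account rests on a few compounds, and the source may have more. Where it says the series, first, only, none or still open, it means among the compounds named here.

Compound 3 `O=S(=O)(c1ccccc1Cl)c1cn(C2CCCNC2)c2ncccc12` stands second highest of the three numbers in an assay on HeLa cells for displacement of a labelled ligand from 5-hydroxytryptamine receptor 6 (Homo sapiens); on this read-out lower numbers stand for stronger inhibition and higher numbers for weaker inhibition: compound 3 gives 3.7 nM, with compound 2 `CN1CCC(n2cc(S(=O)(=O)c3ccc(Cl)cc3)c3cccnc32)C1` at 4.2 nM nearest to it and within the scatter, and compound 1 `CN1CCC(n2cc(S(=O)(=O)c3ccccc3Cl)c3cccnc32)C1` at 2.2 nM furthest from it, also within the scatter. Compound 4 `O=S(=O)(c1ccc(Cl)cc1)c1cn(C2CCCNC2)c2ncccc12` awaits measurement. Its change from compound 3 is 4-chlorophenyl in place of 2-chlorophenyl on a sulfonyl sulfur. The same change has been made once already, within the pair that carries the other side chain on the aromatic nitrogen, and there it gave a 1.9-fold higher number from compound 1 to compound 2 (0.28 log units; within the scatter). The remaining measured step, a 1.7-fold higher number from compound 1 to compound 3 (0.23 log units; within the scatter), concerns the side chain rather than the chlorophenyl group and does not speak to the present change. Going by the values given here, from the one relevant step the expected outcome for compound 4 is a somewhat higher number than for compound 3, most likely still inside the scatter, estimated as a 1.9-fold higher number from compound 3 to compound 4 (0.28 log units; within the scatter). Compound 4 is therefore estimated at 7 nM, in a range from 3 nM to 16 nM.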

Compound 4, inhibition constant: 7.6 nM
For compound 4 the middle estimate is 1.1-fold (0.04 log units) below the measured one; the measured number falls inside the stated range.
By their numbers in this assay, from the lowest: compounds 1, 3, 2 and 4 (each within the scatter of the next, the first and the last beyond it).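

In this assay, 4-chlorophenyl in place of 2-chlorophenyl on a sulfonyl sulfur now reads on a second core, giving a 2.1-fold higher number from compound 3 to compound 4 (0.31 log units; beyond the scatter), a modest step of nearly the same size as before: the same change on two cores in this assay, a 1.9-fold higher number (0.28 log units; within the scatter) from compound 1 to compound 2 and a 2.1-fold higher number (0.31 log units; beyond the scatter) from compound 3 to compound 4, 1.1-fold (0.03 log units) apart, within the scatter of two such steps

The side-chain change, piperidin-3-yl in place of 1-methylpyrrolidin-3-yl on an aromatic nitrogen, also repeats with 4-chlorophenyl in place, giving a 1.8-fold higher number from compound 2 to compound 4 (0.26 log units; within the scatter): the same change on two cores in this assay, a 1.7-fold higher number (0.23 log units; within the scatter) from compound 1 to compound 3 and a 1.8-fold higher number (0.26 log units; within the scatter) from compound 2 to compound 4, 1.1-fold (0.03 log units) apart, within the scatter of two such steps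

Across these four compounds, neither step depends visibly on the group at the other place.

Still open, from the compounds shown here alone, is whether the chlorine itself matters on the sulfonyl sulfur, which a plain phenyl or a methoxyphenyl there would address. The side-chain step also joins two differences, ring size and the methyl group, and an unmethylated pyrrolidine would separate them.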